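Compound 3 to compound 4: an added methyl

This account rests on a few compounds, and the source may have more. Where it says the series, first, only, none or still open, it means among the compounds named here.

Compound 3 `CN(C)C(=O)N(C)CC#CCn1ccnc1` gives > 100 mg/kg in a functional assay on the whole organism for agonist activity, with Mus musculus as the target (on this read-out higher numbers stand for an effect only at larger amounts of compound and lower numbers for an effect already at smaller amounts), which is a limit of the assay and not a number. Compound 4 `Cc1cncn1CC#CCN(C)C(=O)N(C)C` differs from it by methyl in place of hydrogen on an aromatic carbon. Among the measured compounds shown here, no measured pair isolates this change.

Compound 1 `CC(=O)N(C)CC#CCn1cncc1C`, which already carries this methyl, gives > 100 mg/kg, also a limit. Compound 2 `CCOC(=O)N(C)CC#CCn1cncc1C`, which carries it too, gives > 100 mg/kg, again a limit. For the measured compounds named here, the only measured step, a step that the two limits leave unreadable from compound 1 to compound 2, concerns the group on the carbonyl carbon and gives no size to carry over.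

Compounds 1 and 2 show no measurable effect with the methyl in place, and no readable gain is expected for compound 4 because of the limit of > 100 mg/kg in this assay, at which 3 of the 3 values shown sit. The expected change is a step that the limit leaves unreadable from compound 3 to compound 4, with no step beyond the scatter and no favoured direction. Compound 4 will most likely also report only as a limit. For compound 4 the estimated value is 150 mg/kg, with an expected range of 60 mg/kg to 400 mg/kg.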

Compound 4, dose for half-maximal effect: > 100 mg/kg
Compound 4 gave a limit, no number; the forecaster's own chance of this, stated with the estimate: 80%; the middle value is on the limit's open side.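

Compound 4 gives > 100 mg/kg in this assay, a limit and not a number. None of its steps from compound 1, compound 2 or compound 3 can be read. The compounds shown leave open whether the added methyl or the group on the carbonyl carbon alters the dose for half-maximal effect at all.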